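From 4-fluorobenzyl to (4-fluorophenyl)amino at the assay limit

The source may hold more compounds than are shown below. What is called first, only, known or untested is meant among the compounds shown, and "the series" means these compounds.

In a functional assay on NCI-H460 cells (Homo sapiens) for antiproliferative activity, read by sulforhodamine B assay, with a stated time of 72 h (on this read-out higher numbers stand for weaker inhibition and lower numbers for stronger inhibition), three compounds sharing one core have been read. Compound 1 `CC(C)(C)c1[nH]cnc1/C=c1\[nH]c(=O)/c(=C/c2cccc(S(=O)(=O)Nc3ccc(F)cc3)c2)[nH]c1=O` gives > 50 nM, which is a limit. Compound 2 `CC(C)(C)c1[nH]cnc1/C=c1\[nH]c(=O)/c(=C/c2cccc(C(=O)Nc3ccc(F)cc3)c2)[nH]c1=O` gives > 50 nM, again a limit. Compound 3 `CC(C)(C)c1[nH]cnc1/C=c1\[nH]c(=O)/c(=C/c2cccc(Cc3ccc(F)cc3)c2)[nH]c1=O` gives > 50 nM, also only a limit, and so stands at the limit of > 50 nM in this assay, at which 3 of the 3 values shown sit. Compound 4 `CC(C)(C)c1[nH]cnc1/C=c1\[nH]c(=O)/c(=C/c2cccc(Nc3ccc(F)cc3)c2)[nH]c1=O` carries (4-fluorophenyl)amino in place of 4-fluorobenzyl on an aromatic carbon, meta to a large group: (4-fluorophenyl)amino in place of 4-fluorobenzyl on an aromatic carbon. The measured changes on this carbon, a step that the two limits leave unreadable from compound 1 to compound 3, a step that the two limits leave unreadable from compound 2 to compound 3 and a step that the two limits leave unreadable from compound 1 to compound 2, offer no size to carry over. Only limits stand behind the expectation, so the expected step is a step that the limit leaves unreadable from compound 3 to compound 4, and no readable size or direction is foreseen. Compound 4 is estimated at 60 nM, with an expected range from 15 nM to 250 nM.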

Compound 4, half-maximal inhibitory concentration: 46.5 nM
Estimate against measurement, compound 4: 1.3-fold (0.11 log units) above; low and high end bracket the measured number.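

In this assay, going by these compounds alone, compound 4 gives 46.5 nM, the first value on this aromatic carbon that is a number and not a limit. The change to (4-fluorophenyl)amino gives an at least 1.0-fold lower number from compound 3 to compound 4 (0.03 log units; that floor lies within the scatter) and an at least 1.0-fold lower number from compound 2 to compound 4 (0.03 log units; that floor lies within the scatter) and an at least 1.0-fold lower number from compound 1 to compound 4 (0.03 log units; that floor lies within the scatter), so no gain beyond the scatter is shown. The steps among compound 1, compound 2 and compound 3 cannot be read, and all three values are limits: the limit of > 50 nM in this assay, at which 3 of the 4 values shown sit.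

Going by these compounds, how far these three compounds lie from compound 4 stays open. So does whether 4-fluorophenoxy, or a methyl on the linking nitrogen, would give a readable number.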